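The source may hold more compounds than are shown below. What is called first, only, known or untested is meant among the compounds shown, and "the series" means these compounds.

Measured compounds:
compound 1 `CNc1ncc(-c2cccc(Cl)c2)c(-c2ccccc2)n1`, 75%
compound 2 `OCCCCNc1ncc(-c2cccc(Cl)c2)c(-c2ccccc2)n1`, > 80%

In an assay on CHO cells for displacement of a labelled ligand from adenosine receptor A1 (Homo sapiens), read by scintillation counting, with a stated time of 1 h, tested at 1 uM (on this read-out lower numbers stand for less inhibition and higher numbers for more inhibition at the one concentration tested (going by the name of the read-out)), compound 1 gives 75%. Compound 2 reaches only a limit of the assay, > 80%, and so stands at the limit of > 80% in this assay, at which 1 of the 2 values shown sits, its true value open upward. Compound 3 `Clc1cccc(-c2cnc(NCCCc3ccccc3)nc2-c2ccccc2)c1` differs from compound 2 by phenyl in place of hydroxymethyl on a saturated chain carbon, three bonds along the chain from a nitrogen on an aromatic ring. For the measured compounds named here, the single measured step, a number at least 5 percentage points higher from compound 1 to compound 2 (that floor lies within the scatter), lies on the same chain but does not test this exchange, and its own size is open-ended. Nothing measured bears directly on phenyl in place of hydroxymethyl. Compound 3 is therefore expected to stay near the limit, with an estimated step that the limit leaves unreadable from compound 2 to compound 3 and an estimated value of 85%, ranging from 65% to 98%.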

Compound 3, a percentage reported as inhibition, at one concentration (the size of the read-out at that concentration, not a potency): 33%
The estimate for compound 3 lay 52 percentage points above the measured number; the measured number lies below the stated range.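

In this assay, what ends the chain at this place clearly matters: phenyl in place of hydroxymethyl gives a number at least 47 percentage points lower from compound 2 to compound 3 (beyond the scatter). Chain extension alone therefore does not preserve the read-out, as phenethyl in place of hydrogen gives a number 42 percentage points lower from compound 1 to compound 3 (beyond the scatter). The value of compound 2 is a limit, so the first of these steps has only a floor: the limit of > 80% in this assay, at which 1 of the 3 values shown sits.

As far as these compounds go, whether the drop goes with phenyl entering or hydroxymethyl leaving stays open. Also open, from the compounds shown here alone, is how an amine or a carboxylic acid at the chain end, or a longer chain ending in phenyl, would read.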